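Fewer fluorines on the benzyl ring: cytotoxicity of compound 3

The source may report more compounds than this note shows. Statements on the series, on what has been measured and on what is new or still open speak of the compounds shown alone.

Compound 1 `COc1cccc2c1c(C(=O)/C=C(\O)C(=O)O)cn2Cc1ccccc1F` in an ADME assay on MT4 cells (Homo sapiens) for cytotoxicity, read by MTT assay (a higher number here means that more compound is tolerated, a lower number that less compound is tolerated), gives 70500 nM. Compound 2 `COc1cccc2c1c(C(=O)/C=C(\O)C(=O)O)cn2Cc1c(F)ccc(F)c1F` in this assay gives 49400 nM. Among the measured compounds shown here, the only measured step is a 1.4-fold lower number from compound 1 to compound 2 (0.15 log units; within the scatter), so compound 2 stands within the scatter of compound 1, the sole other measured compound. Compound 3 `COc1cccc2c1c(C(=O)/C=C(\O)C(=O)O)cn2Cc1ccc(F)cc1` carries 4-fluorophenyl in place of 2,3,6-trifluorophenyl on a saturated chain carbon bound to an aromatic nitrogen. That earlier step also swapped fluorines on this same ring without leaving the scatter, so the expected step in this assay is a 1.3-fold higher number from compound 2 to compound 3 (0.10 log units; within the scatter), no real change. Compound 3 is therefore estimated at 62000 nM, within 35000 nM to 110000 nM.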

Compound 3, half-maximal cytotoxic concentration: 41100 nM
Compound 3: middle estimate off by 1.5-fold (0.18 log units), on the high side, within the range that was stated.
By their numbers in this assay, from the lowest: compounds 3, 2 and 1 (each within the scatter of the next).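

Replacing 2,3,6-trifluorophenyl with 4-fluorophenyl leaves the number in this assay within the scatter (a 1.2-fold lower number from compound 2 to compound 3 (0.08 log units; within the scatter)), and the same holds when 4-fluorophenyl replaces 2-fluorophenyl (a 1.7-fold lower number from compound 1 to compound 3 (0.23 log units; within the scatter)). All three fluorophenyl groups on this saturated chain carbon bound to an aromatic nitrogen therefore lie within the scatter of one another, so moving or removing fluorines on this ring shows no real change in tolerated concentration. No supporting evidence bears on this result.

From the compounds shown here alone, whether a group other than a fluorophenyl at this place, such as an amine or a longer carbon chain, would shift the number remains open.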